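The source may report more compounds than this note shows. Statements on the series, on what has been measured and on what is new or still open speak of the compounds shown alone.

In an ADME assay on L02 cells (Homo sapiens) for cytotoxicity, read by MTT assay, with a stated time of 48 h (a lower number here means a stronger inhibitor, a higher number a weaker inhibitor), compound 2 `COC(=O)CC1CCN(C[C@H]2CN(c3ccc(-n4cc(-c5ccccn5)cn4)c(F)c3)C(=O)O2)CC1` gives > 400 ug/mL, which is a limit of the assay. Compound 1 `CN(CCC#N)C[C@H]1CN(c2ccc(-n3cc(-c4ccccn4)cn3)c(F)c2)C(=O)O1` likewise reaches a limit in this assay, namely > 400 ug/mL. Both values sit at the same limit (the limit of > 400 ug/mL in this assay, at which 2 of the 2 values shown sit), so the step that the two limits leave unreadable from compound 1 to compound 2 shows nothing readable. Compound 3 `O=C1O[C@@H](CN2CCC(c3ccc(F)cc3)CC2)CN1c1ccc(-n2cc(-c3ccccn3)cn2)c(F)c1` differs from compound 2 by 4-fluorophenyl in place of (methoxycarbonyl)methyl on a saturated ring carbon. Among the measured compounds shown here, no measured step gives a readable size, so no direction beyond the scatter is expected. Compound 3 is therefore expected to give 450 ug/mL, within a range from 250 ug/mL to 900 ug/mL. The step that the limit leaves unreadable from compound 2 to compound 3 that this estimate means is expected to stay within the scatter.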

Compound 3, half-maximal inhibitory concentration: > 400 ug/mL
Compound 3 was reported as a limit; the forecaster's own chance of this, stated with the estimate: 70%; the middle value is on the limit's open side.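

Among the compounds shown here, compound 2 and compound 3 both stop at a limit of the assay, so no step between them can be read: the limit of > 400 ug/mL in this assay, at which 3 of the 3 values shown sit.
The compounds shown leave open how far each lies past that limit, and so whether exchanging these groups changes the value at all.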